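The source may hold more compounds than are shown below. What is called first, only, known or untested is meant among the compounds shown, and "the series" means these compounds.

Measured so far:
compound 1, `Cc1cc(-c2ccc(Cl)cc2)c(S(C)(=O)=O)cc1C(=O)N=C(N)N`: in a functional assay for inhibition of sodium/hydrogen exchanger (Oryctolagus cuniculus) (a lower number here means a stronger inhibitor, a higher number a weaker inhibitor), compound 1 gives 45 nM
compound 2, `Cc1cc(-c2ccccc2)c(S(C)(=O)=O)cc1C(=O)N=C(N)N`: in this assay compound 2 gives 19 nM
compound 3, `Cc1cc(Oc2ccccc2)c(S(C)(=O)=O)cc1C(=O)N=C(N)N`: in this assay compound 3 gives 10 nM

The shared core carries a methylsulfonyl group and an acylguanidine, and the three measured compounds differ only in the aryl substituent. Between compound 2 and compound 1 the change is chloro in place of hydrogen on an aromatic carbon; it brings a 2.4-fold higher number from compound 2 to compound 1 (0.37 log units; beyond the scatter). Between compound 2 and compound 3 the two cores differ by phenoxy in place of phenyl on an aromatic carbon, which gives a 1.9-fold lower number from compound 2 to compound 3 (0.28 log units; within the scatter). From compound 1 to compound 3 the step is a 4.5-fold lower number from compound 1 to compound 3 (0.65 log units; beyond the scatter).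

Compound 4, `Cc1cc(Oc2ccccc2Cl)c(S(C)(=O)=O)cc1C(=O)N=C(N)N`, is not yet measured. It differs from compound 3 by chloro in place of hydrogen on an aromatic carbon. This is the same kind of change as that from compound 2 to compound 1, but the place differs: there the chloro sits para to a large group, here ortho to a large group. Compound 4 is expected to show a 2.0-fold higher number from compound 3 to compound 4 (0.30 log units; within the scatter), resting on the earlier 2.4-fold higher number from compound 2 to compound 1 (0.37 log units; beyond the scatter), with a wider margin because the place is not the same. In this assay compound 4 is estimated at 20 nM, between 8 nM and 50 nM.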

Compound 4, half-maximal inhibitory concentration: 14 nM
Beside the measured number, compound 4's estimate is 1.4-fold (0.15 log units) above it, and the stated range covers the measured number.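

In this assay, chloro in place of hydrogen on the phenoxy group gives a 1.4-fold higher number from compound 3 to compound 4 (0.15 log units; within the scatter), and this step does not differ from the earlier step on the phenyl group by more than repeated measurement allows: the same change on two cores in this assay, a 2.4-fold higher number (0.37 log units; beyond the scatter) from compound 2 to compound 1 and a 1.4-fold higher number (0.15 log units; within the scatter) from compound 3 to compound 4, 1.7-fold (0.23 log units) apart, within the scatter of two such steps

Across these two pairs, then, the change carries from one core to the other with no detectable difference in size, while 2-chlorophenoxy gives a 1.4-fold lower number from compound 2 to compound 4 (0.13 log units; within the scatter) against phenyl and a 3.2-fold lower number from compound 1 to compound 4 (0.51 log units; beyond the scatter) against 4-chlorophenyl. Among the compounds shown here, this does not show that the step is the same on both cores: the new step alone lies within the scatter, only two pairs are available, and the chloro stands in a different place in each, so the place and the core cannot be told apart.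

The compounds shown leave open how 4-chlorophenoxy itself would read in this series, which would separate place from core. They also leave open whether a methoxy group or a nitrile in place of chloro would follow the same course.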